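The source may hold more compounds than are shown below. What is called first, only, known or untested is meant among the compounds shown, and "the series" means these compounds.

Of the compounds shown here, three of one shared core have so far been tested in a functional assay on the whole organism with Rattus norvegicus as the target, at a dose of 20 mg/kg by the intraperitoneal route (on this read-out higher numbers stand for more inhibition at the one dose given (going by the name of the read-out) and lower numbers for less inhibition), each carrying a different substituted benzene ring on that core. Compound 1, with the structure `CCOc1ccccc1-c1nc(N)nc(N)n1`, gives -5% in this assay, which is the lowest of the three numbers. Compound 3, with the structure `Nc1nc(N)nc(-c2ccc([N+](=O)[O-])cc2)n1`, gives 41% in this assay, a number well beyond the usual scatter above compound 1. Compound 2, with the structure `Nc1nc(N)nc(-c2cc(Cl)ccc2F)n1`, gives 89% in this assay, the furthest from compound 1 and again beyond the scatter.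

Compound 4, with the structure `Nc1nc(N)nc(-c2ccccc2Cl)n1`, has not yet been measured. It differs from compound 1 in one place: chloro in place of ethoxy on an aromatic carbon.

For the measured compounds named here, no measured pair differs in exactly this way, so the size of the step is a matter of expectation only. Because compound 2 reaches 89% with halogens on its benzene ring, the step of a number 60 percentage points higher from compound 1 to compound 4 (beyond the scatter) is expected to be upward and beyond the scatter. The expected value for compound 4 in this assay is 55%, with a range from 20% to 90%.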

Compound 4, a percentage reported as inhibition, in the whole organism at one dose (the size of the read-out at that dose, not a potency): 36%
Beside the measured number, compound 4's estimate is 19 percentage points above it; measured number inside the range.
By their numbers in this assay, from the lowest: compound 1; then compounds 4 and 3 (each within the scatter of the next); then compound 2.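

At this aromatic carbon, ortho to a group of 8 heavy atoms, putting chloro in place of ethoxy has a large effect in this assay: the change is a number 41 percentage points higher from compound 1 to compound 4 (beyond the scatter). For the compounds shown here, none of the earlier compounds formed a pair differing in one place, so this step is the first to tie a change in the number to this position alone. Nothing measured here explains the step, and it cannot separate the loss of ethoxy from the arrival of chloro.

Going by these compounds, what a methoxy, a fluoro or an amine would give at this same aromatic carbon stays open. So does whether the same exchange would produce a similar step at other carbons of the ring.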